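A Second Methyl on a Weak Cytotoxic Compound

The source may report more compounds than this note shows. Statements on the series, on what has been measured and on what is new or still open speak of the compounds shown alone.

Compound 1 (`Cc1ccc(C2CN(S(=O)(=O)c3ccccc3)C(=O)N2)cc1`) reads > 316000 nM in a functional assay on A549 cells (Homo sapiens) for cytotoxicity (a lower number here means a stronger inhibitor, a higher number a weaker inhibitor), which is a limit and not a number. Among its relatives, compound 2 (`O=C1NC(c2ccc(Cl)cc2)CN1S(=O)(=O)c1ccc2c(c1)CCC2`) gives 86300 nM and compound 3 (`O=C1NC(c2ccccc2)CN1S(=O)(=O)c1ccccc1`) gives 145000 nM. Compound 4 (`Cc1ccc(C2CN(S(=O)(=O)c3ccc(C)cc3)C(=O)N2)cc1`) differs from compound 1 by methyl in place of hydrogen on an aromatic carbon, a change from phenyl to 4-methylphenyl. Among the compounds with values here, the only measured step involving a methyl is an at least 2.1-fold lower number from compound 1 to compound 3 (0.33 log units; beyond the scatter), where a methyl is lost at another place in the molecule. It therefore offers only a loose guide, and no large move is expected, with any shift more likely toward a higher number. The estimated step is a step that the limit leaves unreadable from compound 1 to compound 4. For compound 4 the expected value is 320000 nM, with an estimated range of 130000 nM to 800000 nM.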

Compound 4, half-maximal inhibitory concentration: > 302000 nM
Compound 4: a limit, no number (the forecaster's own chance of this, stated with the estimate: 50%); the middle value does not contradict the limit.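

Compound 1 and compound 4 each give only a limit in this assay, and the step between them cannot be read. The compounds shown leave open whether the change from phenyl to 4-methylphenyl shifts the reading at all.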